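Adding an amino group to compound 3

The source may hold more compounds than are shown below. What is called first, only, known or untested is meant among the compounds shown, and "the series" means these compounds.

Measured in an ADME assay on a cell-free system (plasma, Homo sapiens) for protein binding:
- Compound 1 `CNc1nccc(N2CC[C@H](NC(=O)Nc3ccc(Cl)c(C(F)(F)F)c3)C2)n1`: 99.8%
- Compound 2 `CCNc1nccc(N2CC[C@H](NC(=O)Nc3ccc(Cl)c(C(F)(F)F)c3)C2)n1`: > 99.9%, a limit of the assay
- Compound 3 `O=C(Nc1ccc(Cl)c(C(F)(F)F)c1)N[C@H]1CCN(c2ccncn2)C1`: 99.3%

Compound 3 has the largest unbound fraction of the three, at 99.3%. Compound 4 `Nc1nccc(N2CC[C@H](NC(=O)Nc3ccc(Cl)c(C(F)(F)F)c3)C2)n1` carries amino in place of hydrogen on an aromatic carbon, between two ring nitrogen atoms: amino in place of hydrogen on an aromatic carbon. Going by the values given here, two measured steps bear on this change when read in reverse: a 3.5-fold higher unbound fraction from compound 1 to compound 3 (0.54 log units; beyond the scatter) and an at least 7.0-fold higher unbound fraction from compound 2 to compound 3 (0.84 log units; beyond the scatter). Both removed a substituted amino group from that carbon. Amino carries no alkyl chain, so a smaller step towards less free compound is expected, possibly within the scatter. For compound 4 the estimate is 99.5%, with an expected range from 98.9% to 99.8%. This would be an expected a 1.4-fold lower unbound fraction from compound 3 to compound 4 (0.15 log units; within the scatter).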

Compound 4, plasma protein binding in the Homo sapiens assay: 99.5%
Compound 4: middle estimate and measured number agree at the digits printed, and the stated range covers the measured number.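

In the Homo sapiens assay amino on this carbon stays within the scatter (a 1.4-fold lower unbound fraction from compound 3 to compound 4 (0.15 log units; within the scatter)), while hydrogen in place of methyl or ethyl on its nitrogen gives more free compound (a 2.5-fold higher unbound fraction from compound 1 to compound 4 (0.40 log units; beyond the scatter) and an at least 5.0-fold higher unbound fraction from compound 2 to compound 4 (0.69 log units; beyond the scatter)). Compound 2 stands at a limit of the assay: the limit of > 99.9% in the Homo sapiens assay, at which 1 of the 4 values shown sits. In a physicochemical assay for solubility, measured as kinetic solubility (a lower number here means a less soluble compound, a higher number a more soluble compound), compound 3 gives 2400 nM and compound 4 gives 30300 nM. In the physicochemical assay the same change on this carbon comes with a large rise in solubility: the measured solubility of compound 3, 2400 nM, and of compound 4, 30300 nM, a 13-fold higher number (1.10 log units; beyond the scatter). The compounds shown leave open whether a hydroxyl or a methoxy group on this carbon would behave as amino does in both read-outs.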